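Compound 3 to compound 4: thiophen-2-yl for 3-chlorophenyl

A few compounds are considered here, and "the series" means these few. Any claim that something is new, unique, unknown or untested is made for them only; others in the source may bear on it.

Of the compounds shown here, three on the shared core have been read in a functional assay on K562 cells (Homo sapiens) for antiproliferative activity, read by MTT assay, with a stated time of 24 h; on this read-out lower numbers stand for stronger inhibition and higher numbers for weaker inhibition. Compound 1 (`COc1ccc(C(=O)/C=C/c2ccc(Br)cc2)c2c1C=CC(C)(C)O2`) gives > 10000 nM as a limit of the assay and not a number. Among the measured compounds shown here, compound 2 (`COc1ccc(C(=O)/C=C/c2ccc([N+](=O)[O-])cc2)c2c1C=CC(C)(C)O2`) gives 7770 nM as the only true number so far. Compound 3 (`COc1ccc(C(=O)/C=C/c2cccc(Cl)c2)c2c1C=CC(C)(C)O2`) gives > 10000 nM as a limit of the assay and not a number. With the limit of > 10000 nM in this assay, at which 2 of the 3 values shown sit, as its reference point, compound 3 has no exact place in the series.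

Compound 4 (`COc1ccc(C(=O)/C=C/c2cccs2)c2c1C=CC(C)(C)O2`) carries thiophen-2-yl in place of 3-chlorophenyl on a double-bonded chain carbon bound to a double-bonded chain carbon.

Two measured steps change the aromatic group and have a readable floor: an at least 1.2-fold lower number from compound 1 to compound 2 (0.10 log units; that floor lies within the scatter) and an at least 1.2-fold higher number from compound 2 to compound 3 (0.10 log units; that floor lies within the scatter) are both small on the numbers available. The third step, a step that the two limits leave unreadable from compound 1 to compound 3, gives no size at all. Neither floor goes beyond the scatter. With an at least 1.2-fold higher number from compound 2 to compound 3 (0.10 log units; that floor lies within the scatter) as the closest guide, no step beyond the scatter is expected in this assay for the new ring. The estimated change is a number no higher from compound 3 to compound 4 (the limit leaves the size open). For compound 4 the estimated value is 10000 nM with an expected range from 5000 nM to 20000 nM in this read-out.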

Compound 4, half-maximal inhibitory concentration: > 10000 nM
Compound 4 gave a limit, no number; the forecaster's own chance of this, stated with the estimate: 60%; the middle value sits exactly at the limit.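

In this assay compound 4 gives > 10000 nM, a limit of the assay and not a number, so thiophen-2-yl on a double-bonded chain carbon bound to a double-bonded chain carbon gives no readable value, and the earlier compounds had shown only six-membered aromatic rings of carbon at this place. Against the one true number in the series, the only readable result is an at least 1.2-fold higher number from compound 2 to compound 4 (0.10 log units; that floor lies within the scatter), and this floor does not tell how large the real gap is. The steps from compound 1 and from compound 3 to compound 4 cannot be read, and the series now rests largely on a single reference point: the limit of > 10000 nM in this assay, at which 3 of the 4 values shown sit.

From the compounds shown here alone, how far compounds 1, 3 and 4 lie past that limit stays open, and with it any ranking among them or any firm reading of the change of ring. Also open, going by these compounds, is whether the number of compound 2 is tied to its nitro group in particular, or whether an amine or a carboxylic acid on the same aromatic carbon would also give a true number.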